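The source may report more compounds than this note shows. Statements on the series, on what has been measured and on what is new or still open speak of the compounds shown alone.

Measured compounds in a functional assay on HT cells (Homo sapiens) for antiproliferative activity, read by fluorescence, with a stated time of 72 h; a higher number here means a weaker inhibitor of growth, a lower number a stronger inhibitor of growth:
- compound 1 `CC(C)c1n[nH]c2c(NCc3ccc(-c4ccccn4)cc3)nc(SCC(O)CO)nc12`: 21 nM
- compound 2 `CC(C)c1n[nH]c2c(NCc3ccc(-c4ccccn4)cc3)nc(SCC(C)(C)O)nc12`: 507 nM
- compound 3 `CC(C)c1n[nH]c2c(NCc3ccc(-c4ccccn4)cc3)nc(SC3CCCCC3O)nc12`: 636 nM

Compound 3 gives the highest number of the three in this assay, but its gap to compound 2 lies within the scatter, so the two are not told apart; only compound 1 stands clearly apart, by a 30-fold higher number from compound 1 to compound 3 (1.48 log units; beyond the scatter).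

Compound 4 `CC(C)c1n[nH]c2c(NCc3ccc(-c4ccccn4)cc3)nc(SCCn3ccnc3)nc12` is not yet measured. 2-(1H-imidazol-1-yl)ethyl in place of 2-hydroxycyclohexyl on a sulfur

Among the compounds with values here, no measured step touches an imidazole. Within the data shown here, the steps that bear on the change are those on the sulfur substituent: a 24-fold higher number from compound 1 to compound 2 (1.38 log units; beyond the scatter) and a 30-fold higher number from compound 1 to compound 3 (1.48 log units; beyond the scatter), both large, against a 1.3-fold higher number from compound 2 to compound 3 (0.10 log units; within the scatter), within the scatter. Both weak compounds differ from compound 1 in what sits on the sulfur, so the region is sensitive; the change to compound 4 removes the last hydroxyl and is expected to give at most a small step, a 1.4-fold higher number from compound 3 to compound 4 (0.15 log units; within the scatter).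

Compound 4 is expected to give about 900 nM in this assay, with a range from 200 nM to 4000 nM.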

Compound 4, concentration for 50% growth inhibition: 155 nM
Estimate against measurement, compound 4: 5.8-fold (0.76 log units) above, and the stated range ends above it.
By their numbers in this assay, from the lowest: compound 1; then compound 4; then compounds 2 and 3 (each within the scatter of the next).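

Within this assay the 2-(1H-imidazol-1-yl)ethyl group gives a 4.1-fold lower number from compound 3 to compound 4 (0.61 log units; beyond the scatter) and a 3.3-fold lower number from compound 2 to compound 4 (0.51 log units; beyond the scatter) with no hydroxyl on the sulfur substituent, so a hydroxyl is not required there for a gain over these two compounds. The 2,3-dihydroxypropyl group stays ahead, with a 7.4-fold higher number from compound 1 to compound 4 (0.87 log units; beyond the scatter) as the remaining gap. Nothing available explains these steps.

Whether the imidazole ring itself matters stays open, since no other nitrogen-bearing group on the sulfur is shown. A 2-aminoethyl chain or a carboxylic acid in this place would test how far the gain extends.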